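The source may hold more compounds than are shown below. What is called first, only, known or untested is meant among the compounds shown, and "the series" means these compounds.

Measured so far in an assay on isolated protein with metabotropic glutamate receptor 2 (Homo sapiens) as the target; on this read-out higher numbers stand for an effect only at larger amounts of compound and lower numbers for an effect already at smaller amounts:
- Compound 1 `CCS(=O)(=O)N(Cc1cccnc1)c1ccc(C(O)c2ccccc2)cc1`: its value is a limit of this assay, > 30000 nM
- Compound 2 `CCS(=O)(=O)N(Cc1cccnc1)c1cccc(C(O)c2ccccc2)c1`: 2500 nM
- Compound 3 `CCS(=O)(=O)N(Cc1cccnc1)c1ccc(C(C)c2ccccc2)cc1`: 1400 nM

Compound 3 and compound 2 lie within the usual scatter of each other; the value of compound 1 is a limit only. Compound 4 `CCS(=O)(=O)N(Cc1cccnc1)c1ccc(COc2ccccc2)cc1` differs from compound 3 by phenoxymethyl in place of 1-phenylethyl on an aromatic carbon. For the measured compounds named here, only one measured step touches this part of the molecule: an at least 21-fold lower number from compound 1 to compound 3 (1.33 log units; beyond the scatter). That step removed a hydroxy and hydrogen-bond acceptor, while the new change brings one acceptor back, though as an ether rather than a hydroxy. A step back toward higher numbers is therefore expected, of moderate size, a 2.5-fold higher number from compound 3 to compound 4 (0.40 log units; beyond the scatter). Compound 4 is estimated at 3500 nM, with a range from 900 nM to 14000 nM.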

Compound 4, half-maximal effective concentration: 2100 nM
Compound 4: the middle estimate sits 1.7-fold (0.22 log units) above what was measured; measured number inside the range.
By their numbers in this assay, from the lowest: compounds 3, 4 and 2 (each within the scatter of the next). At a limit, above all of these: compound 1.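

In this assay, swapping 1-phenylethyl for phenoxymethyl makes no clear difference: a 1.5-fold higher number from compound 3 to compound 4 (0.18 log units; within the scatter). An ether oxygen, with its hydrogen-bond acceptor, can therefore stand at this position without the loss seen with hydroxy(phenyl)methyl: an at least 14-fold lower number from compound 1 to compound 4 (1.15 log units; beyond the scatter). That step gives only a minimum size, as compound 1 sits at a limit of the assay: the limit of > 30000 nM in this assay, at which 1 of the 4 values shown sits.

As far as these compounds go, whether an amine or a carboxylic acid on the phenyl ring would keep the number in this range remains open. So does the effect of a longer chain in place of phenoxymethyl.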